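Inverting a Stereocentre on the Chain of Compound 2

This account rests on a few compounds, and the source may have more. Where it says the series, first, only, none or still open, it means among the compounds named here.

Compound 1 `CC(C)n1nc(N2CC(C(C)(C)O)C2)c2cnc(Nc3ccnc(-c4cnn(S(=O)(=O)C5CC5)c4)n3)cc21` and compound 2 `CC[C@@H](C)n1nc(N2CC(C(C)(C)O)C2)c2cnc(Nc3ccnc(-c4cnn(S(=O)(=O)C5CC5)c4)n3)cc21` share one core and differ only by a methyl in place of hydrogen on a saturated chain carbon, two bonds along the chain from an aromatic nitrogen. In an ADME assay on cells (Hepatocyte, Homo sapiens) for pharmacokinetics (on this read-out lower numbers stand for slow clearance and higher numbers for fast clearance), compound 1 gives 7.1 mL/min/kg, and in this assay compound 2 gives 7.8 mL/min/kg, so the move a 1.1-fold higher number from compound 1 to compound 2 (0.04 log units; within the scatter) says nothing about a real change. Compound 2 therefore stands alongside compound 1 rather than apart from it, the two numbers lying within the scatter of each other.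

Compound 3 `CC[C@H](C)n1nc(N2CC(C(C)(C)O)C2)c2cnc(Nc3ccnc(-c4cnn(S(=O)(=O)C5CC5)c4)n3)cc21` is the mirror partner at that chain carbon: the two compounds have the same atoms and bonds and differ only in configuration as drawn: 1 of 1 stereo elements differ; a stereocentre at a saturated chain carbon is drawn R in compound 2 and S in compound 3. Among the compounds with values here, no measured step addresses an inversion of configuration; the only step available, from compound 1 to compound 2, concerns the creation of the centre itself and stayed within the scatter. With no evidence for a direction, the step is expected to be a 1.0-fold lower number from compound 2 to compound 3 (0.02 log units; within the scatter), that is, none beyond the scatter. Compound 3 is thus estimated at 7.5 mL/min/kg in this assay, with a range from 4 mL/min/kg to 14 mL/min/kg.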

Compound 3, clearance in the Hepatocyte assay: 2.7 mL/min/kg
Compound 3: the middle estimate sits 2.8-fold (0.44 log units) above what was measured; measured number below the stated range.
By their numbers in the Hepatocyte assay, from the lowest: compound 3; then compounds 1 and 2 (each within the scatter of the next).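

In the Hepatocyte assay compound 1 gives 7.1 mL/min/kg, compound 2 gives 7.8 mL/min/kg and compound 3 gives 2.7 mL/min/kg; the inversion at the saturated chain carbon gives a 2.9-fold lower number from compound 2 to compound 3 (0.46 log units; beyond the scatter), and the methyl in place of hydrogen, which drawn R gave a 1.1-fold higher number from compound 1 to compound 2 (0.04 log units; within the scatter), gives a 2.6-fold lower number from compound 1 to compound 3 (0.42 log units; beyond the scatter) when drawn S, so at this position the outcome of adding the methyl depends on its configuration. In a physicochemical assay for solubility, in phosphate buffer, measured as kinetic solubility, with a stated time of 24 h, at pH 7.4, tested at 100 uM (on this read-out higher numbers stand for higher solubility and lower numbers for lower solubility), compound 2 gives 2000 nM and compound 3 gives 2000 nM, and the same inversion gives no change at the digits printed from compound 2 to compound 3 (within the scatter), which means that the mirror partners separate on clearance and not on solubility. The gap in clearance can be assigned to the stereocentre alone because no other structural feature separates the pair: the fact that compounds 2 and 3 differ only in the configuration as drawn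

What the compounds shown leave open is whether the lower clearance of the form drawn S would carry over to a longer chain at this carbon, or to a chain bearing a hydroxyl group. They also show only that configuration at this carbon goes with a difference in clearance, and they leave open the process that lies behind that difference.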